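The source may hold more compounds than are shown below. What is called first, only, known or untested is meant among the compounds shown, and "the series" means these compounds.

Of the compounds shown here, three have been measured in a functional assay on HEK293 cells for agonist activity at D(4) dopamine receptor (Homo sapiens), read by FLIPR; on this read-out lower numbers stand for an effect already at smaller amounts and higher numbers for an effect only at larger amounts of compound. Compound 1 `Cc1ccc(C(=O)NCN2CCC(c3cccc[n+]3[O-])CC2)cc1C` gives 38 nM in this assay, and compound 2 `Cc1cc(NC(=O)CN2CCC(c3cccc[n+]3[O-])CC2)ccc1F` gives 18 nM. Compound 3 `Cc1cccc(NC(=O)CN2CCC(c3nccs3)CC2)c1` gives 1 nM, the lowest of the three numbers; its nearest neighbour is compound 2, whose number lies higher by an amount beyond the usual scatter, and compound 1 lies further away still. Compound 4 `COc1ccccc1C1CCN(CC(=O)Nc2cccc(C)c2)CC1` has not yet been measured. It differs from compound 3 in one place: 2-methoxyphenyl in place of 1,3-thiazol-2-yl on a saturated ring carbon. Going by the values given here, no pair of the measured compounds differs in only one place, so there is no directly comparable step to lean on. Compounds 1 and 2 carry a different group on the saturated ring carbon and sit at higher numbers than compound 3, but they also differ elsewhere, so that comparison is loose. For compound 4 a modest move toward higher numbers is expected, within or a little beyond the scatter. The expected step is a 6.0-fold higher number from compound 3 to compound 4 (0.78 log units; beyond the scatter). Compound 4 is therefore estimated at 6 nM, with a range from 1.5 nM to 25 nM.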

Compound 4, half-maximal effective concentration: 420 nM
Compound 4: middle estimate off by 70-fold (1.85 log units), on the low side; measured number outside the range, above it.
By their numbers in this assay, from the lowest: compound 3; then compound 2; then compound 1; then compound 4.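

Going by these compounds alone, this is the first step in which only one place changes, so it gives a direct reading of the group on the saturated ring carbon, three ring bonds from the ring nitrogen. In this assay, 2-methoxyphenyl in place of 1,3-thiazol-2-yl gives a 420-fold higher number from compound 3 to compound 4 (2.62 log units; beyond the scatter), a large step, so the number depends strongly on which aromatic ring sits at this carbon. No measurement shown here accounts for the size of this step.

The two groups differ at once in ring size, in hetero atoms and in the methoxy group, and a single step cannot separate these differences. As far as these compounds go, a plain phenyl ring or 1,3-oxazol-2-yl at this carbon would be a closer comparison with either compound, and how either would read remains open.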